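Aryl amide change at the weakest compound of the series

The source may report more compounds than this note shows. Statements on the series, on what has been measured and on what is new or still open speak of the compounds shown alone.

Measured compounds in a functional assay on MCF7 cells (Homo sapiens) for antiproliferative activity, read by MTT assay, with a stated time of 72 h; on this read-out lower numbers stand for stronger inhibition and higher numbers for weaker inhibition:
compound 1, `Cc1cc(NCCN(C)C)nc2ccc(NC(=O)c3ccc(Cl)c(Cl)c3)cc12`: 2550 nM
compound 2, `CCN1CCN(c2cc(C)c3cc(NC(=O)c4cc(Cl)cc(Cl)c4)ccc3n2)CC1`: 6090 nM
compound 3, `Cc1cc(N2CCN(C(C)C)CC2)nc2ccc(NC(=O)c3ccc(Cl)c(Cl)c3)cc12`: 1710 nM

Compound 2 stands highest of the three numbers in this assay. Its nearest neighbour is compound 1, and the gap between compound 2 and compound 1 is beyond the scatter, as is the larger gap to compound 3, so compound 2 is the weakest of the measured set. Within the data shown here, the one single-point step, a 1.5-fold lower number from compound 1 to compound 3 (0.17 log units; within the scatter), concerns the group on the aromatic carbon of the shared core and lies within the scatter.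

Compound 4, `CCN1CCN(c2cc(C)c3cc(NC(=O)c4ccc(C)cc4)ccc3n2)CC1`, is not yet measured. It differs from compound 2 at the amide end: 4-methylphenyl in place of 3,5-dichlorophenyl on a carbonyl carbon. Among the measured compounds shown here, no measured step bears on this change; compound 1 and compound 3 carry a different dichlorophenyl from compound 2 but also differ from it elsewhere, so their values say nothing single-handed about the amide aryl group.

For the measured compounds named here, with no bearing step, the expectation rests on compound 2 alone. Compound 4 is expected at 8000 nM, with a range from 2500 nM to 25000 nM. The expected step is thus a 1.3-fold higher number from compound 2 to compound 4 (0.12 log units; within the scatter), not firmly beyond the scatter in either direction.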

Compound 4, half-maximal inhibitory concentration: 6740 nM
The estimate for compound 4 lay 1.2-fold (0.07 log units) above the measured number, and the stated range covers the measured number.
By their numbers in this assay, from the lowest: compounds 3 and 1 (each within the scatter of the next); then compounds 2 and 4 (each within the scatter of the next).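

In this assay the amide end of the series now has its first single-change reading, and 4-methylphenyl in place of 3,5-dichlorophenyl on a carbonyl carbon gives a 1.1-fold higher number from compound 2 to compound 4 (0.04 log units; within the scatter). With the rest of the structure held as in compound 2, this position therefore tolerates the loss of both chlorine atoms and the arrival of a methyl-bearing phenyl ring without a change beyond the scatter, so neither aryl group stands apart from the other in this pair. No supporting measurement is available to account for this flat step.

Among these compounds, the pair covers only two substituted phenyl groups on one background, so it remains open whether a phenyl ring carrying an amine or a carboxylic acid, or a saturated ring such as cyclohexyl, would move the number at this carbonyl carbon. Going by these compounds, it is equally open whether the same exchange would read as flat on the backgrounds of compound 1 and compound 3, where the group on the aromatic carbon of the shared core differs from that of compound 2.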